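The compounds below may be only part of what the source reports. "The series", "measured", "known", "first", "only" and "open" are said of these compounds alone.

Compound 1 `Cc1ccc(-n2cc(CNC(=O)c3cccc4c3cnn4C(C)C)nn2)cc1C` is the 3,4-dimethylphenyl member of the series. In a functional assay on HepG2 cells (Homo sapiens) for inhibition, read by MTT assay, with a stated time of 72 h (on this read-out higher numbers stand for weaker inhibition and lower numbers for stronger inhibition), compound 1 gives > 40000 nM, which is a limit of the assay and not a number. Compound 2 `Cc1ccc(-n2cc(CNC(=O)c3cccc4c3cnn4C(C)C)nn2)c(C)c1` carries 2,4-dimethylphenyl in place of 3,4-dimethylphenyl on an aromatic nitrogen. In this assay compound 2 gives > 40000 nM, again a limit rather than a number. The step that the two limits leave unreadable from compound 1 to compound 2 is therefore unreadable, and compound 2 stands on (the limit of > 40000 nM in this assay, at which 2 of the 2 values shown sit), with no readable step anywhere in the set. Compound 3 `CC(C)n1ncc2c(C(=O)NCc3cn(Cc4ccccc4)nn3)cccc21` differs from compound 2 by benzyl in place of 2,4-dimethylphenyl on an aromatic nitrogen. Within the data shown here, no measured step bears on this change, so no direction beyond the scatter is expected. Compound 3 is estimated at 40000 nM, within 12000 nM to 100000 nM, most likely reported as a limit. The expected step is a number no higher from compound 2 to compound 3 (the limit leaves the size open).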

Compound 3, half-maximal inhibitory concentration: 13700 nM
Beside the measured number, compound 3's estimate is 2.9-fold (0.47 log units) above it; measured number inside the range.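

Among these compounds, on an aromatic nitrogen of the five-membered ring, benzyl gives the only value in this assay that is not a limit, and the change shows an at least 2.9-fold lower number from compound 2 to compound 3 (0.46 log units; beyond the scatter) and an at least 2.9-fold lower number from compound 1 to compound 3 (0.46 log units; beyond the scatter). This position therefore responds to a change of group, which compound 1 and compound 2 could not show, and the step between those two still cannot be read: the limit of > 40000 nM in this assay, at which 2 of the 3 values shown sit.

As far as these compounds go, the full size of both steps stays open. Also open, from the compounds shown here alone, is whether phenethyl, a longer chain on this nitrogen, or an amine on the benzyl ring would move the number further.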